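Sulfamate series: piperidin-1-yl replaces the bromobenzyl amine

A few compounds are considered here, and "the series" means these few. Any claim that something is new, unique, unknown or untested is made for them only; others in the source may bear on it.

Three compounds share the same sulfamate-bearing core and differ only in the amine on the benzoyl ring. Compound 1 `NS(=O)(=O)Oc1ccc2c(c1)CN(C(=O)c1cccc(N3CCC(N4CCCCC4)CC3)c1)CC2` gives 8% in an assay on HEK293 cells for inhibition of Steryl-sulfatase (Homo sapiens), tested at 1 uM; on this read-out lower numbers stand for a weaker effect and higher numbers for a stronger effect at the one concentration tested. Compound 2 `CCN(Cc1ccc(Br)cc1)c1cccc(C(=O)N2CCc3ccc(OS(N)(=O)=O)cc3C2)c1` gives 84.5% in this assay, the second highest of the three numbers. Compound 3 `CCN(Cc1ccc(Br)cc1)c1ccc(C(=O)N2CCc3ccc(OS(N)(=O)=O)cc3C2)cc1` gives 95.9% in this assay; compound 3 is the nearest to compound 2, higher by a margin beyond the scatter, while compound 1 is the furthest, lower by a margin far beyond the scatter.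

Compound 4 `NS(=O)(=O)Oc1ccc2c(c1)CN(C(=O)c1cccc(N3CCCCC3)c1)CC2` is not yet measured. It differs from compound 2 in one place: piperidin-1-yl in place of (4-bromobenzyl)(ethyl)amino on an aromatic carbon. For the measured compounds named here, no step between measured compounds covers this change. Compound 1, whose amine is likewise a non-aromatic ring with no aromatic ring attached, stands far below compound 2, so a drop in this assay well beyond the scatter is expected. Compound 4 is therefore estimated at 22%, within a range of 5% to 50%. The expected step of a number 62.5 percentage points lower from compound 2 to compound 4 (beyond the scatter) is a marked loss of inhibition.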

Compound 4, a percentage reported as inhibition, at one concentration (the size of the read-out at that concentration, not a potency): 11.9%
The estimate for compound 4 lay 10.1 percentage points above the measured number; low and high end bracket the measured number.
By their numbers in this assay, from the lowest: compounds 1 and 4 (each within the scatter of the next); then compound 2; then compound 3.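

In this assay the change from (4-bromobenzyl)(ethyl)amino to piperidin-1-yl on this aromatic carbon gives a number 72.6 percentage points lower from compound 2 to compound 4 (beyond the scatter) and so shows that the inhibition of compound 2 is not kept when this position carries the smaller ring with no aromatic ring in it. The further comparison gives a number 3.9 percentage points higher from compound 1 to compound 4 (within the scatter) and so shows that the piperidin-1-yl on the saturated ring carbon of compound 1 makes no difference that can be told apart in this read-out. No measurement shown here bears on why the large step occurs.

Which part of the departing group carries the inhibition remains open, whether the bromine, the ethyl or the benzyl ring. A plain benzylamino group or a 4-chlorobenzylamino group at this position would begin to separate these parts.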